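Swapping chloro for methoxy on a single enantiomer

A few compounds are considered here, and "the series" means these few. Any claim that something is new, unique, unknown or untested is made for them only; others in the source may bear on it.

Compound 2, with the structure `CC#C[C@@H](CC(=O)O)c1ccc(OC[C@H]2COc3ccc(Cl)cc3O2)cc1`, gives the lowest number of the three measured compounds in a functional assay on HEK293 cells for agonist activity at Free fatty acid receptor 1 (Homo sapiens), read by fluorescence and calcium flux, with a stated time of 10 min (on this read-out lower numbers stand for an effect already at smaller amounts and higher numbers for an effect only at larger amounts of compound), namely 50 nM. Compound 1, drawn without defined configuration as `CC#CC(CC(=O)O)c1ccc(OCC2COc3ccc(Cl)cc3O2)cc1`, gives 100 nM in this assay, and the step of a 2.0-fold lower number from compound 1 to compound 2 (0.30 log units; within the scatter) stays within the scatter. Compound 3, the mirror image drawn as `CC#C[C@H](CC(=O)O)c1ccc(OC[C@@H]2COc3ccc(Cl)cc3O2)cc1`, gives 5040 nM, and the step of a 100-fold higher number from compound 2 to compound 3 (2.00 log units; beyond the scatter) is large; that step rests on (the fact that compounds 2 and 3 differ only in the configuration as drawn).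

Going by the values given here, compound 4, with the structure `CC#C[C@@H](CC(=O)O)c1ccc(OC[C@H]2COc3ccc(OC)cc3O2)cc1`, keeps the configuration of compound 2 and changes only one group: methoxy in place of chloro on an aromatic carbon. Among the compounds with values here, none of the measured steps bears on this exchange, since every one of them concerns configuration alone and leaves the chloro in place. The expectation for this assay therefore rests on compound 2 alone, with a wide band around it. The estimated step of a 2.4-fold higher number from compound 2 to compound 4 (0.38 log units; beyond the scatter) is expected to be modest and not clearly beyond the scatter. Compound 4 is estimated at 120 nM, within a range from 30 nM to 500 nM.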

Compound 4, half-maximal effective concentration: 130 nM
Beside the measured number, compound 4's estimate is 1.1-fold (0.03 log units) below it; the measured number falls inside the stated range.
By their numbers in this assay, from the lowest: compounds 2, 1 and 4 (each within the scatter of the next, the first and the last beyond it); then compound 3.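

In this assay, going by these compounds alone, the exchange of chloro for methoxy gives a 2.6-fold higher number from compound 2 to compound 4 (0.41 log units; beyond the scatter) and is the first measured change at this place on the aromatic ring, since every earlier step altered configuration alone. The step is modest yet beyond the scatter, so this position on this enantiomer accepts methoxy, with its extra heavy atom and its hydrogen-bond acceptor, at the cost of only a small shift in the number. Nothing in the information at hand bears on why the number moves with this exchange.

As far as these compounds go, how a fluoro, a nitrile, an amine or a longer chain such as ethoxy would behave at this place remains open. Also open, from the compounds shown here alone, is whether methoxy in place of chloro would shift the number in the same way on the mirror-image form, compound 3.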